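Swapping the Triazole Substituent on a Weak MCF7 Inhibitor

A few compounds are considered here, and "the series" means these few. Any claim that something is new, unique, unknown or untested is made for them only; others in the source may bear on it.

Of the compounds shown here, two carrying the shared core have been measured in a functional assay on MCF7 cells (Homo sapiens) for inhibition, read by MTT assay, with a stated time of 24 h; a higher number here means a weaker inhibitor, a lower number a stronger inhibitor. Compound 1 `CCOC(=O)C1=Cc2ccccc2OC1(OCc1cn(CC(=O)Nc2ccc(OC)cc2)nn1)C(F)(F)F` gives 28100 nM in this assay. Compound 2 `O=C(O)C1=Cc2ccccc2OC1(OCc1cc(-c2ccc(F)cc2)no1)C(F)(F)F` gives 64200 nM in this assay. Compound 1 therefore stands at the lower of the two numbers, with compound 2 above it by a gap beyond the scatter; on this scale both compounds are weak inhibitors.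

Compound 3 `CCOC(=O)C1=Cc2ccccc2OC1(OCc1cn(-c2cccc(C(F)(F)F)c2)nn1)C(F)(F)F` has not yet been measured. It differs from compound 1 in a single place: 3-(trifluoromethyl)phenyl in place of ((4-methoxyphenyl)carbamoyl)methyl on an aromatic nitrogen. Among the compounds with values here, no pair of measured compounds differs in this way alone, so the size of the step cannot be read from the data, and compound 1 and compound 2 differ from each other in more than one place.

The change is therefore expected to move the number by no more than the scatter, in no fixed direction, and the expected step is a 1.1-fold higher number from compound 1 to compound 3 (0.03 log units; within the scatter). Compound 3 is expected to give 30000 nM in this assay, with a range from 10000 nM to 90000 nM.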

Compound 3, half-maximal inhibitory concentration: > 150000 nM
Compound 3 was reported as a limit (the forecaster's own chance of this, stated with the estimate: 15%); middle value at least 5.0-fold (0.69 log units) from the limit.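

Going from ((4-methoxyphenyl)carbamoyl)methyl to 3-(trifluoromethyl)phenyl on this aromatic nitrogen gives an at least 5.3-fold higher number from compound 1 to compound 3 (0.72 log units; beyond the scatter) in this assay, which shows that the group here matters for this read-out, something compound 1 and compound 2 could not show, as they differ in more than one place. The value of compound 3 is a limit and not a number, so this step fixes only the smallest size of the change and not its full size: the limit of > 150000 nM in this assay, at which 1 of the 3 values shown sits. The change replaces a group that has a hydrogen-bond donor and hydrogen-bond acceptors with one that has neither, while a six-membered aromatic ring of carbon only is present on both sides, but a single step cannot say which of these differences counts.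

The compounds shown leave open whether the amide hydrogen, the methoxy group or the trifluoromethyl group accounts for the step. They also leave open how a plain benzyl group, or a phenyl ring carrying an amine or a hydroxyl group, would read on this nitrogen in this assay.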